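Sulfonamide Aryl Swap: From Dihydrobenzofuran to Difluorophenyl

A few compounds are considered here, and "the series" means these few. Any claim that something is new, unique, unknown or untested is made for them only; others in the source may bear on it.

Measured in an assay on MDA-MB-231 cells for binding affinity to C-X-C chemokine receptor type 4 (Homo sapiens), read by microscopy, with stated times of 10 min and 30 min; on this read-out lower numbers stand for an effect already at smaller amounts and higher numbers for an effect only at larger amounts of compound:
compound 1 `O=C(NCc1ccc(CNS(=O)(=O)c2ccccc2)cc1)c1ccc(CNc2ncccn2)cc1`, 1 nM
compound 2 `O=C(NCc1ccc(CNS(=O)(=O)c2ccc3c(c2)CCO3)cc1)c1ccc(CNc2ncccn2)cc1`, 1000 nM
compound 3 `O=C(NCc1ccc(CNS(=O)(=O)c2ccc(-c3ccc(F)cc3)cc2)cc1)c1ccc(CNc2ncccn2)cc1`, 1000 nM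

Compound 2 gives 1000 nM in this assay, level with compound 3 at the digits shown and together with it the highest of the three numbers; compound 1 sits far lower. Compound 4 `O=C(NCc1ccc(CNS(=O)(=O)c2ccc(F)c(F)c2)cc1)c1ccc(CNc2ncccn2)cc1` differs from compound 2 at the sulfonyl sulfur: a group of 8 heavy atoms (6 carbon, 2 fluorine; one six-membered aromatic ring of carbon only) in place of a group of 9 heavy atoms (8 carbon, 1 oxygen; one five-membered non-aromatic ring with 1 hetero atom, one six-membered aromatic ring of carbon only), on a sulfonyl sulfur. For the measured compounds named here, no measured step matches this change directly. The steps of a 1000-fold higher number from compound 1 to compound 2 (3.00 log units; beyond the scatter) and a 1000-fold higher number from compound 1 to compound 3 (3.00 log units; beyond the scatter) show that enlarging the phenyl on the sulfonyl sulfur, in two different ways, raised the number sharply; compound 4 instead carries a phenyl with two fluorines, closer in size to the phenyl of compound 1. Compound 4 is therefore expected to move back toward compound 1, with a step of a 33-fold lower number from compound 2 to compound 4 (1.52 log units; beyond the scatter). The estimate for compound 4 is 30 nM, ranging from 3 nM to 1000 nM.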

Compound 4, effective concentration (reported as EC, without a stated level of effect): 100 nM
Estimate against measurement, compound 4: 3.3-fold (0.52 log units) below; measured number inside the range.
By their numbers in this assay, from the lowest: compound 1; then compound 4; then compounds 2 and 3 (each within the scatter of the next).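

In this assay, for the compounds shown here, 3,4-difluorophenyl on the sulfonyl sulfur gives a 10-fold lower number from compound 2 to compound 4 (1.00 log units; beyond the scatter), so changing the aryl group at this position need not cost as much as the earlier compounds suggested. Still, it does not recover the result for the plain phenyl, with a 100-fold higher number from compound 1 to compound 4 (2.00 log units; beyond the scatter), so each of the three replacements shown for phenyl raises the number by a large step. Nothing measured here accounts for either step. From the compounds shown here alone, it remains open whether a single fluorine, a methoxy group or an amine on the phenyl would stay closer to compound 1. The compounds shown also do not separate the contributions of the two fluorines.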